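Swapping methylsulfanyl for a selenium group on two cores

The source may report more compounds than this note shows. Statements on the series, on what has been measured and on what is new or still open speak of the compounds shown alone.

Compound 1 `CS/C(=N\C(=O)c1ccno1)NC(=O)c1ccno1` and compound 3 `CS/C(=N\C(=O)c1cnc2ccccc2c1)NC(=O)c1cnc2ccccc2c1` both carry a methylsulfanyl group on a carbon with a double bond to nitrogen, but they are built on different cores; the difference between the two cores is not broken down here. In a functional assay on K562 cells (Homo sapiens) for cytotoxicity, read by MTT assay, with a stated time of 72 h (a lower number here means that less compound is tolerated, a higher number that more compound is tolerated), compound 1 gives > 100000 nM, which is a limit of the assay rather than a number. Compound 3 likewise gives > 100000 nM in this assay, again a limit. Compound 2 `O=C(/N=C(/NC(=O)c1ccno1)[Se]Cc1ccccc1)c1ccno1` arises from compound 1 by a group of 8 heavy atoms (7 carbon, 1 selenium; one six-membered aromatic ring of carbon only) in place of a group of 2 heavy atoms (1 carbon, 1 sulfur; no ring), on a carbon with a double bond to nitrogen. In this assay compound 2 gives 94700 nM, and the step of an at least 1.0-fold lower number from compound 1 to compound 2 (0.02 log units; that floor lies within the scatter) therefore lies within the scatter. Compound 4 `O=C(/N=C(/NC(=O)c1cnc2ccccc2c1)[Se]Cc1ccccc1)c1cnc2ccccc2c1` is made from compound 3 by the same change, (a group of 8 heavy atoms (7 carbon, 1 selenium; one six-membered aromatic ring of carbon only) in place of a group of 2 heavy atoms (1 carbon, 1 sulfur; no ring), on a carbon with a double bond to nitrogen), at a place described in identical words. Because the limit of > 100000 nM in this assay, at which 2 of the 3 values shown sit, marks where both methylsulfanyl compounds sit, and because an at least 1.0-fold lower number from compound 1 to compound 2 (0.02 log units; that floor lies within the scatter) stayed within the scatter, compound 4 is expected to remain near that limit. The expected step of a number no higher from compound 3 to compound 4 (the limit leaves the size open) is thus small. Compound 4 is estimated at 100000 nM, with a likely range from 50000 nM to 200000 nM.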

Compound 4, concentration lethal to 50% of the cells: > 100000 nM
Compound 4 gave a limit, no number (the forecaster's own chance of this, stated with the estimate: 50%); the middle value sits exactly at the limit.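

In this assay, no step can be read from compound 3 to compound 4, because both compounds give a limit and not a number: the limit of > 100000 nM in this assay, at which 3 of the 4 values shown sit.

The compounds shown leave open whether replacing methylsulfanyl with the selenium-containing group changes the tolerated concentration at all on the core of compound 3.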